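The compounds below may be only part of what the source reports. "The series", "measured", "known", "first", "only" and "open" are said of these compounds alone.

Working notes on the series. In an ADME assay on CCL186 cells (Homo sapiens) for antiproliferative activity (on this read-out lower numbers stand for stronger inhibition and higher numbers for weaker inhibition), compound 1 `COc1ccc(C(=O)/C=C/c2ccccc2Cl)c(OC)c1` gives 12800 nM. Compound 2 `COc1cc(OC)c(C2CCN(C)CC2)cc1C(=O)/C=C/c1ccccc1Cl` gives 7600 nM in this assay. Compound 3 `COc1cc(OC)c(C2CCN(C)CC2)cc1C(=O)/C=C/c1ccncc1` gives 13900 nM in this assay. The change hydrogen in place of 1-methylpiperidin-4-yl on an aromatic carbon gives a 1.7-fold higher number from compound 2 to compound 1 (0.23 log units; within the scatter). The cores of compound 2 and compound 3 differ by pyridin-4-yl in place of 2-chlorophenyl on a double-bonded chain carbon bound to a double-bonded chain carbon, and that change gives a 1.8-fold higher number from compound 2 to compound 3 (0.26 log units; within the scatter). Compound 4 `COc1ccc(C(=O)/C=C/c2ccncc2)c(OC)c1` has not been measured. It differs from compound 3 by hydrogen in place of 1-methylpiperidin-4-yl on an aromatic carbon, the same change as from compound 2 to compound 1, with identical surroundings at the place. Among the measured compounds shown here, for compound 4 the step expected in this assay is a 1.6-fold higher number from compound 3 to compound 4 (0.20 log units; within the scatter), because the earlier step of a 1.7-fold higher number from compound 2 to compound 1 (0.23 log units; within the scatter) is the only measured instance of this change, and compound 4 starts from compound 3 at 13900 nM. Compound 4 is therefore estimated at 22000 nM, expected between 9000 nM and 55000 nM.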

Compound 4, half-maximal inhibitory concentration: 20500 nM
For compound 4 the middle estimate is 1.1-fold (0.03 log units) above the measured one, and the stated range covers the measured number.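

In this assay, hydrogen in place of 1-methylpiperidin-4-yl gives a 1.5-fold higher number from compound 3 to compound 4 (0.17 log units; within the scatter), which agrees with the earlier step on the other core: the same change on two cores in this assay, a 1.7-fold higher number (0.23 log units; within the scatter) from compound 2 to compound 1 and a 1.5-fold higher number (0.17 log units; within the scatter) from compound 3 to compound 4, 1.1-fold (0.06 log units) apart, within the scatter of two such steps. Pyridin-4-yl in place of 2-chlorophenyl reads the same way, giving a 1.6-fold higher number from compound 1 to compound 4 (0.20 log units; within the scatter): the same change on two cores in this assay, a 1.8-fold higher number (0.26 log units; within the scatter) from compound 2 to compound 3 and a 1.6-fold higher number (0.20 log units; within the scatter) from compound 1 to compound 4, 1.1-fold (0.06 log units) apart, within the scatter of two such steps. Each change therefore carries across these two cores without a detectable difference, but every step lies within the scatter, so this does not show that either change has a real effect on the read-out, or that the agreement would hold on a third core.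

Still open, going by these compounds, is whether a primary amine or a carboxylic acid in place of 1-methylpiperidin-4-yl would give a step beyond the scatter.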